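Working notes: from compound 2 to compound 3

A few compounds are considered here, and "the series" means these few. Any claim that something is new, unique, unknown or untested is made for them only; others in the source may bear on it.

In a functional assay on HeLa cells (Homo sapiens) for inhibition, read by MTT assay, with a stated time of 4 days (on this read-out lower numbers stand for stronger inhibition and higher numbers for weaker inhibition), compound 1 `COc1cc(NC(C)CCCNC(=O)NNC(=O)N(CCO)CCO)c2ncccc2c1` gives > 250000 nM, which is a limit and not a number. In this assay, compound 2 `COc1cc(NC(C)CCCNC(=O)NNC(=O)NCCCO)c2ncccc2c1` gives > 250000 nM, again only a limit. Within the data shown here, compound 2 therefore has no numerical value, and the series so far stands at the limit of > 250000 nM in this assay, at which 2 of the 2 values shown sit. Among the measured compounds shown here, the only measured step is a step that the two limits leave unreadable from compound 1 to compound 2, with (3-hydroxypropyl)amino in place of bis(2-hydroxyethyl)amino on a carbonyl carbon.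

Compound 3 `COc1cc(NC(C)CCCNC(=O)Nc2ccc(Cl)c(C(F)(F)F)c2)c2ncccc2c1`, not yet measured, has 4-chloro-3-(trifluoromethyl)phenyl in place of ((3-hydroxypropyl)carbamoyl)amino on an amide-type nitrogen. The exchange replaces the whole group that carried the difference between the two measured compounds, so it is a much larger change than the measured one. That measured step offers no size to carry over, and the expectation rests on the structural change alone. Stronger inhibition is expected, with wide uncertainty over how much. An estimated at least 16-fold lower number from compound 2 to compound 3 (1.22 log units; beyond the scatter) is expected in this assay. For compound 3 the expected value is 15000 nM, with an estimated range from 3000 nM to 70000 nM.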

Compound 3, half-maximal inhibitory concentration: 3900 nM
The estimate for compound 3 lay 3.8-fold (0.59 log units) above the measured number; measured number inside the range.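

In this assay, among these compounds, 4-chloro-3-(trifluoromethyl)phenyl in place of ((3-hydroxypropyl)carbamoyl)amino on the amide-type nitrogen gives an at least 64-fold lower number from compound 2 to compound 3 (1.80 log units; beyond the scatter), the first change to yield a readable number. The same group in place of (bis(2-hydroxyethyl)carbamoyl)amino gives an at least 64-fold lower number from compound 1 to compound 3 (1.80 log units; beyond the scatter), so this nitrogen tolerates a large exchange, and the gain appears from either of the two starting compounds, with both sizes printed only as lower bounds. The step from compound 1 to compound 2 cannot be read, because neither compound has a number, only a limit: the limit of > 250000 nM in this assay, at which 2 of the 3 values shown sit.

The compounds shown do not separate the contributions of the chlorine, the trifluoromethyl and the aromatic ring of carbon, so it remains open whether an unsubstituted phenyl, a chloro-only phenyl or a saturated cyclohexyl on the same nitrogen would keep the gain. Going by these compounds, it is also open how a carboxylic acid, an amine or a longer alkyl chain at this place would read, and whether changes elsewhere on the shared core would add to the step.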